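The source may hold more compounds than are shown below. What is called first, only, known or untested is meant among the compounds shown, and "the series" means these compounds.

In an ADME assay on HEK293 cells (Homo sapiens) for cytotoxicity, read by resazurin assay, with a stated time of 48 h (on this read-out higher numbers stand for lower toxicity in this test and lower numbers for higher toxicity in this test), three compounds sharing one core have been measured. Compound 1 (`Cc1ccccc1S(=O)(=O)Nc1ccc2oc(-c3ccccc3)nc2c1`) gives 57000 nM, compound 2 (`O=S(=O)(Nc1ccc2oc(-c3ccccc3)nc2c1)c1ccc(Cl)cc1`) gives 65000 nM, and compound 3 (`O=S(=O)(Nc1ccc2oc(-c3ccccc3)nc2c1)c1ccc(Cl)c(Cl)c1`) gives 71000 nM. Compound 3 therefore stands level with the other two, within the scatter of both. The unmeasured compound 4 (`CS(=O)(=O)Nc1ccc2oc(-c3ccccc3)nc2c1`) keeps the same core but carries methyl in place of 3,4-dichlorophenyl on a sulfonyl sulfur.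

For the measured compounds named here, three measured steps bear on this change. Two exchange the group at that same place: a 1.1-fold higher number from compound 1 to compound 2 (0.06 log units; within the scatter) and a 1.2-fold higher number from compound 1 to compound 3 (0.10 log units; within the scatter). The third adds a chloro group to the ring at that place: a 1.1-fold higher number from compound 2 to compound 3 (0.04 log units; within the scatter). All three lie within the scatter. However, each group measured so far on the sulfonyl sulfur contains a six-membered aromatic ring of carbon only, so the data offer no direct precedent for methyl there. No step beyond the scatter is expected in this assay, in either direction, but this expectation is less secure than the measured steps themselves. The expected change is a 1.1-fold lower number from compound 3 to compound 4 (0.04 log units; within the scatter). For compound 4 the estimated value is 65000 nM, with an expected range from 30000 nM to 130000 nM.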

Compound 4, half-maximal cytotoxic concentration: > 100000 nM
Compound 4: a limit, no number; the forecaster's own chance of this, stated with the estimate: 15%; middle value at least 1.5-fold (0.18 log units) from the limit.
By their numbers in this assay, from the lowest: compounds 1, 2 and 3 (each within the scatter of the next). At a limit, above all of these: compound 4.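

For compound 4 in this assay, the reading of > 100000 nM is a limit of the assay and not a number: the limit of > 100000 nM in this assay, at which 1 of the 4 values shown sits. For the compounds shown here, with methyl on the sulfonyl sulfur, the first group at this place without a six-membered aromatic ring of carbon only, the steps are an at least 1.4-fold higher number from compound 3 to compound 4 (0.14 log units; that floor lies within the scatter), an at least 1.5-fold higher number from compound 2 to compound 4 (0.18 log units; that floor lies within the scatter) and an at least 1.7-fold higher number from compound 1 to compound 4 (0.24 log units; that floor lies within the scatter). The result thus extends the flat picture from compounds 1, 2 and 3 to a far smaller group: losing the ring gave no lower number, so in this assay the ring is not needed to keep toxicity in this test as low as those three compounds show it.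

Each of these steps is only a floor within the scatter, so the compounds shown leave open how far compound 4 really lies from the others and whether any of its steps goes beyond the scatter. They also leave open whether a longer alkyl chain, or a chain carrying an amine or a carboxylic acid, on the sulfonyl sulfur would stay as high as methyl or bring the number down.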